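Moving the benzyl halogen: 4-chlorobenzyl to 3-bromobenzyl

The source may report more compounds than this note shows. Statements on the series, on what has been measured and on what is new or still open speak of the compounds shown alone.

In a functional assay on BV-2 cells (Mus musculus), read by Griess assay, with a stated time of 24 h (a lower number here means a stronger inhibitor, a higher number a weaker inhibitor), compound 1 (`CC1COC2(C=CC(=O)C=C2)N(c2ccccc2)C1=O`) gives 1220 nM as its reading. Compound 2 (`O=C1C=CC2(C=C1)OCC(Cc1ccccc1)C(=O)N2c1ccccc1`) gives 570 nM on the same read-out. Compound 3 (`O=C1C=CC2(C=C1)OCC(Cc1ccc(Cl)cc1)C(=O)N2c1ccccc1`) gives 540 nM and stands level with compound 2 within the scatter, while compound 1 lies higher than both. Putting an aromatic group on the chain gave modest changes beyond the scatter: a 2.1-fold lower number from compound 1 to compound 2 (0.33 log units; beyond the scatter) and a 2.3-fold lower number from compound 1 to compound 3 (0.35 log units; beyond the scatter) are the two steps. Adding chloro to the aromatic ring made no difference beyond the scatter: a 1.1-fold lower number from compound 2 to compound 3 (0.02 log units; within the scatter) is the step.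

Compound 4 (`O=C1C=CC2(C=C1)OCC(Cc1cccc(Br)c1)C(=O)N2c1ccccc1`) carries 3-bromophenyl in place of 4-chlorophenyl on a saturated chain carbon bound to a saturated ring carbon is the change. The aromatic ring stays, so the two larger steps bear on it only loosely. Going by the values given here, no measured compound carries bromo, and none tests a different ring position. The closest guide is a 1.1-fold lower number from compound 2 to compound 3 (0.02 log units; within the scatter) and it stayed within the scatter. No step beyond the scatter is therefore expected in this assay in either direction. The estimated step is a 1.0-fold higher number from compound 3 to compound 4 (0.01 log units; within the scatter) and it is expected to stay small. For compound 4 the estimated value is 550 nM with an expected range of 270 nM to 1100 nM on this read-out.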

Compound 4, half-maximal inhibitory concentration: 540 nM
Compound 4: middle estimate off by 1.0-fold (0.01 log units), on the high side, and the stated range covers the measured number.
By their numbers in this assay, from the lowest: compounds 3, 4 and 2 (each within the scatter of the next); then compound 1.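

In this assay, the halogen's identity and its ring position can change together with no shift beyond the scatter, as 3-bromophenyl in place of 4-chlorophenyl gives no change at the digits printed from compound 3 to compound 4 (within the scatter). Going by these compounds alone, this is the first sign that this place, on a saturated chain carbon bound to a saturated ring carbon, tolerates a change of halogen and of ring position at once: bromo in place of hydrogen gives a 1.1-fold lower number from compound 2 to compound 4 (0.02 log units; within the scatter), while the full 3-bromophenyl in place of hydrogen gives a 2.3-fold lower number from compound 1 to compound 4 (0.35 log units; beyond the scatter), so compounds 2, 3 and 4 all read level and compound 1 alone stands apart. No measured information on hand accounts for this flat response.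

Halogen identity and ring position remain unseparated, as compound 4 changes both in a single step, and a 3-chlorobenzyl or 4-bromobenzyl partner would be needed to read each alone. Also open, going by these compounds, is whether a carboxylic acid or an amine on the benzyl ring, or a longer chain in place of the benzyl group, would break this flat pattern.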